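Swapping bromo for acetyl on a urea aryl ring

This account rests on a few compounds, and the source may have more. Where it says the series, first, only, none or still open, it means among the compounds named here.

Measured compounds:
Compound 1, `Cc1cccc(NC(=O)Nc2cc(Oc3ccc4nc(NC(=O)C5CC5)sc4c3)ccc2F)c1`: 580 nM
Compound 2, `O=C(Nc1cccc(Br)c1)Nc1cc(Oc2ccc3nc(NC(=O)C4CC4)sc3c2)ccc1F`: 440 nM
Compound 3, `N#Cc1c(Oc2ccc(F)c(NC(=O)c3cccc(C(F)(F)F)c3)c2)ccc2nc(NC(=O)C3CC3)sc12`: > 20000 nM

In a functional assay on HT-29 cells (Homo sapiens) for inhibition, read by luminescence and CellTiter-Glo, with a stated time of 12 h (a lower number here means that less compound is needed, a higher number that more compound is needed for the effect), compound 1 gives 580 nM. Compound 2 gives 440 nM in this assay, the lowest of the two plain numbers, yet the step of a 1.3-fold lower number from compound 1 to compound 2 (0.12 log units; within the scatter) shows that the two stand within the scatter of each other. Compound 3 reaches only the limit of this assay, > 20000 nM, so it contributes no number; see (the limit of > 20000 nM in this assay, at which 1 of the 3 values shown sits).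

Compound 4, `CC(=O)c1cccc(NC(=O)Nc2cc(Oc3ccc4nc(NC(=O)C5CC5)sc4c3)ccc2F)c1`, has not yet been measured. It differs from compound 2 by one change: acetyl in place of bromo on an aromatic carbon. Going by the values given here, the only measured step that touches the same place is the one from compound 1 to compound 2, where bromo replaced methyl on that aromatic carbon, and that step stayed within the scatter. Nothing measured shows how an acetyl group at this position behaves, and the amide compound 3 sits at a limit, so it gives no guidance on size. The expectation is therefore a step of a 1.6-fold higher number from compound 2 to compound 4 (0.20 log units; within the scatter) that may not rise beyond the scatter, with a wide range to cover the unknown. Compound 4 is estimated at 700 nM in this assay, between 200 nM and 2500 nM.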

Compound 4, half-maximal effective concentration: 1000 nM
Compound 4: the middle estimate sits 1.4-fold (0.15 log units) below what was measured; low and high end bracket the measured number.
By their numbers in this assay, from the lowest: compounds 2, 1 and 4 (each within the scatter of the next, the first and the last beyond it). At a limit, above all of these: compound 3.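

On this aryl ring, a change of group can now be told apart from the scatter: in this assay, acetyl in place of bromo gives a 2.3-fold higher number from compound 2 to compound 4 (0.36 log units; beyond the scatter), a modest shift, whereas the earlier exchange of methyl for bromo stayed within the scatter. Measured against methyl, acetyl gives a 1.7-fold higher number from compound 1 to compound 4 (0.24 log units; within the scatter), which stays within the scatter, so acetyl separates only from bromo and the three groups do not fall into a clear order. The position also accepts acetyl, with its carbonyl and more heavy atoms than bromo, and still gives a plain number rather than a limit, although nothing shown here explains the gap between acetyl and bromo.

Going by these compounds, how this position responds to an amine, a carboxylic acid or a longer chain such as butanoyl remains open, so three groups cannot yet define a trend. On these data alone, compound 3 stands at a limit and differs from the others in more than one place, so the role of the urea link remains open too.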